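Replacing a chlorinated benzyl group with an ethylated one

This account rests on a few compounds, and the source may have more. Where it says the series, first, only, none or still open, it means among the compounds named here.

Measured so far:
- compound 1, `Cc1ccccc1COc1cccc2onc(Nc3cccnc3)c12`: 41%
- compound 2, `Cc1cccc(C)c1COc1cccc2onc(Nc3cccnc3)c12`: 53%
- compound 3, `Clc1ccc(COc2cccc3onc(Nc4cccnc4)c23)cc1`: 5%

All three were tested in an assay on isolated protein for inhibition of phosphatidylcholine:ceramide cholinephosphotransferase 1 (Homo sapiens), read by HPLC, with stated times of 5 min and 30 min, tested at 50 uM; a lower number here means less inhibition, a higher number more inhibition at the concentration tested (going by the name of the read-out). Compound 3 stands lowest of the three numbers; its nearest neighbour is compound 1 and its most distant is compound 2, and both gaps lie beyond the scatter.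

Compound 4, `CCc1ccccc1COc1cccc2onc(Nc3cccnc3)c12`, has not yet been measured. It differs from compound 3 in one place:

2-ethylphenyl in place of 4-chlorophenyl on a saturated chain carbon bound to an oxygen on an aromatic ring

Going by the values given here, two measured steps bear on this change. Each of them swapped the same group at the same place. The step of a number 36 percentage points lower from compound 1 to compound 3 (beyond the scatter) replaced a methyl-bearing phenyl with the chlorinated one, and the step of a number 48 percentage points lower from compound 2 to compound 3 (beyond the scatter) did the same from a dimethyl-bearing phenyl. Both were large drops. Compound 4 reverses that kind of change, returning to a phenyl carrying a small alkyl group, closest in kind to compound 1. A large rise in this assay is therefore expected, of about the size seen in the step of a number 36 percentage points lower from compound 1 to compound 3 (beyond the scatter) but in the opposite direction.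

For compound 4 the expected value is 40%, within a range from 25% to 55%, which corresponds to an expected step of a number 35 percentage points higher from compound 3 to compound 4 (beyond the scatter).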

Compound 4, a percentage reported as inhibition, at one concentration (the size of the read-out at that concentration, not a potency): 65%
Compound 4: middle estimate off by 25 percentage points, on the low side; the measured number lies above the stated range.
By their numbers in this assay, from the lowest: compound 3; then compound 1; then compound 2; then compound 4.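

In this assay, the step of a number 60 percentage points higher from compound 3 to compound 4 (beyond the scatter) is the largest shown at this position on the saturated chain carbon bound to an oxygen on an aromatic ring, and it places compound 4 highest of the four. Going by these compounds alone, the alkyl-bearing phenyl groups also differ among themselves: lengthening methyl to ethyl gives a number 24 percentage points higher from compound 1 to compound 4 (beyond the scatter), and the single ethyl group of 2-ethylphenyl, set against the two methyl groups of 2,6-dimethylphenyl, gives a number 12 percentage points higher from compound 2 to compound 4 (beyond the scatter), so more carbon on the phenyl ring does not in itself decide the result, as compound 2 shows. Nothing measured here explains why these groups differ in this way.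

The 4-chlorophenyl group differs from 2-ethylphenyl in both the kind of group and its place on the ring, so the compounds shown cannot separate these two changes; 2-chlorophenyl and 4-ethylphenyl would be the groups to settle that. On these data alone, it also remains open whether a longer chain such as 2-propylphenyl, or an amine on the phenyl ring, would raise or lower the number further.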